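Swapping bromo for methyl in compound 2

This account rests on a few compounds, and the source may have more. Where it says the series, first, only, none or still open, it means among the compounds named here.

In a functional assay on MGC-803 cells (Homo sapiens) for inhibition, read by CCK-8 assay, with a stated time of 48 h (on this read-out lower numbers stand for stronger inhibition and higher numbers for weaker inhibition), compound 1 `COc1ccc(CN(C(=O)CSC(=S)N2CCN(C(=O)OC(C)(C)C)CC2)c2cc(OC)c(OC)c(OC)c2)cc1` gives 310 nM, and compound 2 `COc1cc(N(Cc2ccc(Br)cc2)C(=O)CSC(=S)N2CCN(C(=O)OC(C)(C)C)CC2)cc(OC)c1OC` gives 12400 nM, the higher of the two numbers and thus the weaker inhibition. Compound 3 `COc1cc(N(Cc2ccc(C)cc2)C(=O)CSC(=S)N2CCN(C(=O)OC(C)(C)C)CC2)cc(OC)c1OC` differs from compound 2 by methyl in place of bromo on an aromatic carbon, para to a large group: methyl in place of bromo on an aromatic carbon. For the measured compounds named here, only one measured step bears on this change. It is a 40-fold higher number from compound 1 to compound 2 (1.60 log units; beyond the scatter), a large step beyond the scatter, which came with bromo in place of methoxy on the same aromatic carbon. Going by the values given here, no methyl compound has been measured, so this single step marks out a span and gives no direct answer. Removing the bromo of compound 2 is expected to recover part of that span, though not all of it, giving a moderate fall in the number in this assay. The expected change is a 6.2-fold lower number from compound 2 to compound 3 (0.79 log units; beyond the scatter), though a single step makes this uncertain. For compound 3 the estimated value is 2000 nM, with an expected range of 350 nM to 10000 nM.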

Compound 3, half-maximal inhibitory concentration: 16700 nM
Compound 3: middle estimate off by 8.4-fold (0.92 log units), on the low side; measured number above the stated range.
By their numbers in this assay, from the lowest: compound 1; then compounds 2 and 3 (each within the scatter of the next).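

In this assay, the step of a 1.3-fold higher number from compound 2 to compound 3 (0.13 log units; within the scatter) lies within the scatter, so bromo and methyl on this aromatic carbon, para to a large group, cannot be told apart, and the weak inhibition of compound 2 is not particular to bromo. Methyl in place of methoxy gives a 54-fold higher number from compound 1 to compound 3 (1.73 log units; beyond the scatter), a large step in the same direction as a 40-fold higher number from compound 1 to compound 2 (1.60 log units; beyond the scatter), so among these three compounds the one with methoxy at this place stands apart from both the bromo and the methyl compounds. Nothing available here accounts for that separation or ties it to any property of the groups.

The compounds shown leave open whether the low number of compound 1 depends on the oxygen of the methoxy or on the group as a whole, a question that a hydroxyl, an ethoxy or an amine on this carbon would help to settle. They also leave open what a plain hydrogen at this place would give, and so whether methoxy raises inhibition or bromo and methyl both lower it.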